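Nitrile to Carboxylic Acid on a Shortened Side Chain

This account rests on a few compounds, and the source may have more. Where it says the series, first, only, none or still open, it means among the compounds named here.

Compound 1, `CCc1cc(C(C)=O)c(O)cc1OCCCCCC(C)(C)C#N`, gives 53% in an assay on isolated protein for binding affinity to leukotriene B4 receptor 1 (Homo sapiens), tested at 1 uM; on this read-out lower numbers stand for less inhibition and higher numbers for more inhibition at the one concentration tested (going by the name of the read-out).
Compound 2, `CCc1cc(C(C)=O)c(O)cc1OCCCCCCCC(C)(C)C#N`, gives 29% in this assay.

Going by the values given here, of the two numbers measured, compound 2 stands at the lower end; its only neighbour is compound 1, which sits higher by the step of a number 24 percentage points lower from compound 1 to compound 2 (beyond the scatter). Among the compounds with values here, that step, a modest drop beyond the scatter, is the single measured change available, and it follows the lengthening of the side chain from compound 1 to compound 2.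

Compound 3, `CCc1cc(C(C)=O)c(O)cc1OCCCCCC(C)(C)C(=O)O`, has not yet been measured. It differs from compound 2 by 1-carboxy-1-methylethyl in place of 3-cyano-3-methylbutyl on a saturated chain carbon, five bonds along the chain from an oxygen on an aromatic ring. Two things happen at once: the chain returns to the length found in compound 1, and the nitrile is replaced by a carboxylic acid. The first part runs the measured step in reverse, so a rise of roughly that size is expected. Within the data shown here, the second part has no measured precedent here, which widens the range. Compound 3 is therefore expected to give about 50%, between 25% and 75%, an expected step of a number 21 percentage points higher from compound 2 to compound 3 (beyond the scatter).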

Compound 3, a percentage reported as inhibition, at one concentration (the size of the read-out at that concentration, not a potency): 73%
Compound 3: the middle estimate sits 23 percentage points below what was measured; measured number inside the range.
By their numbers in this assay, from the lowest: compound 2; then compound 1; then compound 3.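

With the chain length held, carboxy in place of cyano on a saturated chain carbon bound to three saturated chain carbons gives a number 20 percentage points higher from compound 1 to compound 3 (beyond the scatter) in this assay, which shows that the group at the chain end matters as well as the length of the chain. The change that alters both at once, 1-carboxy-1-methylethyl in place of 3-cyano-3-methylbutyl, gives a number 44 percentage points higher from compound 2 to compound 3 (beyond the scatter), so among these compounds the shorter chain and the carboxylic acid both go with a higher number and neither goes against the other. Nothing measured here accounts for the effect of the carboxylic acid on this read-out.

The compounds shown leave open how a carboxylic acid behaves on the longer chain of compound 2, so it cannot be said whether the effects of chain length and of the end group simply add. Going by these compounds alone, they also leave open whether a primary amide or a methyl ester at the same chain end, or a chain shorter than the one in compound 3, would go with a higher or a lower number.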